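A few compounds are considered here, and "the series" means these few. Any claim that something is new, unique, unknown or untested is made for them only; others in the source may bear on it.

Measured so far in a functional assay on the whole organism (strain albino) for inhibition, with Rattus norvegicus as the target, read by paw edema, with stated times of 30 min and 1 h, at a dose of 25 mg/kg by the intraperitoneal route; on this read-out higher numbers stand for more inhibition at the one dose given (going by the name of the read-out) and lower numbers for less inhibition:
Compound 2, `CCOC(=O)C(=O)C(C(=O)c1ccc(OC)cc1OC)c1ccccc1`: 15.1%
Compound 1, `COc1ccc(C2=NN(C(=O)NS(=O)(=O)c3ccc(C)cc3)CC2c2ccccc2)c(OC)c1`: 4.9%

Of these two numbers, compound 2 stands highest; the gap to compound 1 lies beyond the usual scatter of this measurement.

Compound 3, `CCOC(=O)C(=O)C(C)C(=O)c1ccc(OC)cc1OC`, has not yet been measured. It differs from compound 2 by methyl in place of phenyl on a saturated chain carbon bound to two carbonyl carbons. Among the measured compounds shown here, no measured pair shows what this change does, so the expected step is none beyond the scatter, with a small drop considered somewhat more likely than a rise, an expectation of a number 5.1 percentage points lower from compound 2 to compound 3 (within the scatter). On that basis compound 3 is estimated at 10%, with a likely range from 0% to 25%.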

Compound 3, a percentage reported as inhibition, in the whole organism at one dose (the size of the read-out at that dose, not a potency): 23.7%
Compound 3: middle estimate off by 13.7 percentage points, on the low side, within the range that was stated.
By their numbers in this assay, from the lowest: compound 1; then compounds 2 and 3 (each within the scatter of the next).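

In this assay, methyl in place of phenyl on a saturated chain carbon bound to two carbonyl carbons gives a number 8.6 percentage points higher from compound 2 to compound 3 (within the scatter). At this position, then, the aromatic ring of compound 2 is not needed to keep the read-out at the level of that compound, and a single carbon serves as well within the scatter. Nothing measured here explains why the two groups read alike. Still open, on these data alone, is whether a longer chain such as butyl, or an amine, on this same carbon would move the number beyond the scatter.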